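Acetyl in place of dimethylsulfamoyl in a 5-lipoxygenase series

The source may hold more compounds than are shown below. What is called first, only, known or untested is meant among the compounds shown, and "the series" means these compounds.

For the measured compounds named here, compound 2 `CN(C)S(=O)(=O)c1ccc(Sc2cc(C3(C)COC(C)(C)O3)cs2)cc1` gives 210 nM in a functional assay on blood for inhibition of Polyunsaturated fatty acid 5-lipoxygenase (Homo sapiens); a higher number here means a weaker inhibitor, a lower number a stronger inhibitor; compound 1 `CN(c1ccc(Sc2cc(C3(C)COC(C)(C)O3)cs2)cc1)S(C)(=O)=O` gives 160 nM, and the step of a 1.3-fold higher number from compound 1 to compound 2 (0.12 log units; within the scatter) lies within the scatter, so the two compounds stand level on the numbers measured so far. Compound 3 `CC(=O)c1ccc(Sc2cc(C3(C)COC(C)(C)O3)cs2)cc1` differs from compound 2 by acetyl in place of dimethylsulfamoyl on an aromatic carbon. Going by the values given here, only the step of a 1.3-fold higher number from compound 1 to compound 2 (0.12 log units; within the scatter) touches this position, and it stayed within the scatter; the acetyl group itself has no precedent. The expected step is therefore a 1.4-fold higher number from compound 2 to compound 3 (0.15 log units; within the scatter), nothing beyond the scatter. Compound 3 is estimated at 300 nM, with a range from 120 nM to 800 nM.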

Compound 3, half-maximal inhibitory concentration: 600 nM
For compound 3 the middle estimate is 2.0-fold (0.30 log units) below the measured one; the range from low to high includes it.
By their numbers in this assay, from the lowest: compounds 1 and 2 (each within the scatter of the next); then compound 3.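

In this assay, this position on the aromatic carbon is not indifferent to the group it carries: a 2.9-fold higher number from compound 2 to compound 3 (0.46 log units; beyond the scatter) and a 3.8-fold higher number from compound 1 to compound 3 (0.57 log units; beyond the scatter), whereas the exchange between the two sulfonyl-containing groups stayed within the scatter. Acetyl is the first group here to shift the number, and it makes compound 3 a weaker inhibitor than either earlier compound. Nothing available explains this loss.

Going by these compounds, it remains open whether a sulfonyl unit is needed to hold the level of compound 1 and compound 2. A methylsulfonyl group or a primary amide at this position would test that.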